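Ester variation on the shared core

The source may report more compounds than this note shows. Statements on the series, on what has been measured and on what is new or still open speak of the compounds shown alone.

Notes on the series. Going by the values given here, compound 1 `CCC(=O)O[C@@H]1CO[C@H]2[C@@H]1OC[C@@H]2OC(=O)c1ccccc1OC(C)=O` carries a propanoyl ester on the shared core; in an ADME assay on a cell-free system (plasma, Homo sapiens) for metabolic stability, with Plasma (Rattus norvegicus) as the target, read by HPLC, at pH 7.4 (a lower number here means that the compound disappears faster, a higher number that the compound lasts longer), compound 1 gives 0.0608 h, the lowest of the three numbers so far, though its distance to compound 3 and to compound 2 is within the scatter. Compound 2 `CC(=O)Oc1ccccc1C(=O)O[C@H]1CO[C@H]2[C@@H]1OC[C@H]2OC(=O)c1ccc(C)cc1` gives 0.105 h and compound 3 `CC(=O)Oc1ccccc1C(=O)O[C@H]1CO[C@H]2[C@@H]1OC[C@H]2OC(=O)c1ccncc1` gives 0.0617 h.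

Compound 4 `CC(=O)Oc1ccccc1C(=O)O[C@H]1CO[C@H]2[C@@H]1OC[C@H]2OC(=O)c1cnccc1Cl` differs from compound 1 thus: 4-chloropyridin-3-yl in place of ethyl on a carbonyl carbon. Among the compounds with values here, two measured steps bear on this exchange of the ethyl group for an aromatic ring on the same carbonyl carbon: a 1.7-fold higher number from compound 1 to compound 2 (0.24 log units; within the scatter) and a 1.0-fold higher number from compound 1 to compound 3 (0.01 log units; within the scatter). Neither moved the half-life beyond the scatter, so the entering 4-chloropyridin-3-yl group is expected to leave the number near where compound 1 stands, with no direction that can be called. The step is therefore estimated as a 1.2-fold higher number from compound 1 to compound 4 (0.06 log units; within the scatter). For compound 4 the half-life is expected at about 0.07 h, with a range from 0.035 h to 0.14 h.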

Compound 4, half-life: 0.0642 h
Estimate against measurement, compound 4: 1.1-fold (0.04 log units) above; the range from low to high includes it.
By their numbers in this assay, from the lowest: compounds 1, 3, 4 and 2 (each within the scatter of the next).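

In this assay, the 4-chloropyridin-3-yl group, with its chlorine and ring nitrogen, is the third aromatic ring on this carbonyl carbon to stay within the scatter of the ethyl group (a 1.1-fold higher number from compound 1 to compound 4 (0.02 log units; within the scatter)). It also stays within the scatter of both other aromatic rings (a 1.0-fold higher number from compound 3 to compound 4 (0.02 log units; within the scatter); a 1.6-fold lower number from compound 2 to compound 4 (0.21 log units; within the scatter)), so all four groups shown on this carbonyl carbon give half-lives that cannot be told apart. No measurement shown offers an explanation for this result.

On these data alone, whether any group on this carbonyl carbon can move the half-life beyond the scatter stays open, for example a longer chain, an amine or a carboxylic acid. The compounds shown also do not tell whether this ester has any bearing on the half-life.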